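Methoxy in place of trifluoromethyl on the thiourea aryl ring

The source may report more compounds than this note shows. Statements on the series, on what has been measured and on what is new or still open speak of the compounds shown alone.

Compound 1 `NC(=O)c1c(NC(=O)c2ccccc2Cl)sc2c1CCN(Cc1ccccc1Cl)C2` gives 4430 nM in a functional assay on MKN-74 cells (Homo sapiens) for antiproliferative activity, with a stated time of 24 h; on this read-out lower numbers stand for stronger inhibition and higher numbers for weaker inhibition. Compound 2 `CSc1ccccc1NC(=S)N1CCc2c(sc(NC(=O)c3ccccc3Cl)c2C(N)=O)C1` gives 13800 nM in this assay, and compound 3 `NC(=O)c1c(NC(=O)c2ccccc2Cl)sc2c1CCN(C(=S)Nc1ccc(C(F)(F)F)cc1)C2` gives 7090 nM, a number that lies within the scatter of both other compounds. The two measured steps, a 3.1-fold higher number from compound 1 to compound 2 (0.49 log units; beyond the scatter) and a 1.9-fold lower number from compound 2 to compound 3 (0.29 log units; within the scatter), concern the substituent on the amine nitrogen in the ring and the aryl on the amide-type nitrogen. Compound 4 `COc1ccc(NC(=S)N2CCc3c(sc(NC(=O)c4ccccc4Cl)c3C(N)=O)C2)cc1` differs from compound 3 by methoxy in place of trifluoromethyl on an aromatic carbon. Among the measured compounds shown here, no measured step covers this exchange; the only step on the same aryl, a 1.9-fold lower number from compound 2 to compound 3 (0.29 log units; within the scatter), stayed within the scatter, so no change beyond the scatter is expected: a 1.1-fold higher number from compound 3 to compound 4 (0.05 log units; within the scatter). Compound 4 is therefore estimated at 8000 nM, with a range from 3000 nM to 20000 nM.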

Compound 4, half-maximal inhibitory concentration: 19600 nM
Compound 4: middle estimate off by 2.5-fold (0.39 log units), on the low side; the measured number falls inside the stated range.
By their numbers in this assay, from the lowest: compounds 1, 3, 2 and 4 (each within the scatter of the next, the first and the last beyond it).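

Among the compounds shown here, on the thiourea aryl ring, methoxy in place of trifluoromethyl gives a 2.8-fold higher number from compound 3 to compound 4 (0.44 log units; beyond the scatter) in this assay and is the first exchange on this aryl to lie beyond the scatter. With 4-methoxyphenyl in place of 2-(methylsulfanyl)phenyl the result is a 1.4-fold higher number from compound 2 to compound 4 (0.15 log units; within the scatter) and stays within the scatter, while a 4.4-fold higher number from compound 1 to compound 4 (0.65 log units; beyond the scatter) goes with the exchange on the ring amine nitrogen. No evidence at hand bears on why the number moves with this exchange.

From the compounds shown here alone, whether the higher number follows from gaining methoxy or from losing trifluoromethyl stays open. So does what a chlorine, an amine or a carboxylic acid at this place on the ring would give.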